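The compounds below may be only part of what the source reports. "The series", "measured", "known", "first", "only" and "open" are said of these compounds alone.

Measured compounds in a functional assay on HCC1806 cells (Homo sapiens) for inhibition, read by sulforhodamine B assay, tested at 10 uM; a higher number here means more inhibition at the concentration tested (going by the name of the read-out), a lower number less inhibition:

- compound 1 `CC(=O)N1N=C(c2ccc(N3CCN(C)CC3)cc2)CC1c1ccc(N(C)C)cc1`: -0.8%
- compound 2 `CN1CCN(c2ccc(C3=NN(C(=O)/C=C/c4ccccc4)C(c4ccc(N(C)C)cc4)C3)cc2)CC1`: 71%
- compound 3 `CN1CCN(c2ccc(C3=NN(S(=O)(=O)c4ccc(C#N)cc4)C(c4ccc(N(C)C)cc4)C3)cc2)CC1`: 99.8%

Compound 1 stands lowest of the three numbers in this assay. Its nearest neighbour is compound 2, reached by a number 71.8 percentage points higher from compound 1 to compound 2 (beyond the scatter), a large step beyond the scatter; the furthest is compound 3, reached by a number 100.6 percentage points higher from compound 1 to compound 3 (beyond the scatter). Between the two members with the higher numbers the step is a number 28.8 percentage points higher from compound 2 to compound 3 (beyond the scatter), modest but still beyond the scatter. All three measured steps concern the group on the amine nitrogen in the ring; the acetyl of compound 1 goes with the lowest of the three numbers.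

Compound 4 `CC(=O)N1N=C(c2ccc(-n3ccnc3)cc2)CC1c1ccc(N(C)C)cc1` keeps that acetyl and differs from compound 1 elsewhere: 1H-imidazol-1-yl in place of 4-methylpiperazin-1-yl on an aromatic carbon. Among the measured compounds shown here, no measured step touches this position, so nothing here tells how this assay answers a change on the aromatic carbon. With the acetyl retained, the expectation is that compound 4 stays near compound 1, and the expected step of a number 5.8 percentage points higher from compound 1 to compound 4 (within the scatter) is judged to lie within the scatter. The estimate for compound 4 is therefore 5%, ranging from -15% to 30%.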

Compound 4, a percentage reported as inhibition, at one concentration (the size of the read-out at that concentration, not a potency): -9.7%
Compound 4: the middle estimate sits 14.7 percentage points above what was measured, within the range that was stated.
By their numbers in this assay, from the lowest: compounds 4 and 1 (each within the scatter of the next); then compound 2; then compound 3.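

In this assay, the aromatic carbon para to a large group now has its first reading: 1H-imidazol-1-yl in place of 4-methylpiperazin-1-yl gives a number 8.9 percentage points lower from compound 1 to compound 4 (within the scatter). With the acetyl retained, exchanging a six-membered non-aromatic ring for a five-membered aromatic ring, with the same count of hydrogen-bond acceptors, therefore does not shift the read-out beyond the scatter. No supporting measurement bears on this result, and no cause can be assigned to it.

Still open, on these data alone, is whether this position stays equally silent when the ring nitrogen carries the (2-phenylethenyl)carbonyl of compound 2 or the (4-cyanophenyl)sulfonyl of compound 3. Also open, as far as these compounds go, is how this assay answers a morpholin-4-yl group or a carboxylic acid on the same aromatic carbon.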